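A Methyl Added to a Serine-Derived Side Chain

The source may report more compounds than this note shows. Statements on the series, on what has been measured and on what is new or still open speak of the compounds shown alone.

Of the compounds shown here, three have been measured in an ADME assay on CCRF-CEM cells (Homo sapiens) for cytotoxicity; on this read-out lower numbers stand for higher toxicity in this test and higher numbers for lower toxicity in this test. Compound 1 `CC[C@H](C)[C@H](NC(=O)c1cnc2ccccc2c1Cl)C(=O)OC` gives 23.3 uM. Compound 2 `COC(=O)[C@@H](NC(=O)c1cnc2ccccc2c1Cl)C(C)C` gives 17.6 uM. Compound 3 `COC(=O)[C@H](CO)NC(=O)c1cnc2cc(C)ccc2c1Cl` gives 59.6 uM, the highest of the three numbers, with its steps to compound 1 and compound 2 both beyond the scatter.

Compound 1 and compound 2 share a core and differ in one place: methyl in place of hydrogen on a saturated chain carbon, three bonds along the chain from an amide-type nitrogen and a carbonyl carbon. That change gave a 1.3-fold higher number from compound 2 to compound 1 (0.12 log units; within the scatter), a step that lies within the scatter. Compound 3 carries a core that differs from that of compound 2, and the difference between the two cores is not broken down here.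

Compound 4 `COC(=O)[C@@H](NC(=O)c1cnc2cc(C)ccc2c1Cl)[C@@H](C)O` has not yet been measured. It differs from compound 3 by methyl in place of hydrogen on a saturated chain carbon bound to an oxygen on a saturated carbon and a saturated chain carbon. Among the measured compounds shown here, this is the same kind of change as the one from compound 2 to compound 1, but the place is not the same: there the new methyl sat on a saturated chain carbon three bonds along the chain from an amide-type nitrogen and a carbonyl carbon, here it sits on a saturated chain carbon bound to an oxygen on a saturated carbon and a saturated chain carbon.

For the measured compounds named here, the expectation for compound 4 rests on the single earlier example, in which the added methyl barely moved the number, as a 1.3-fold higher number from compound 2 to compound 1 (0.12 log units; within the scatter) shows. On that basis compound 4 is expected to give 65 uM in this assay, between 30 uM and 130 uM. The step this estimate means is expected to be a 1.1-fold higher number from compound 3 to compound 4 (0.04 log units; within the scatter).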

Compound 4, half-maximal toxic concentration: > 100 uM
Compound 4: a limit, no number; the forecaster's own chance of this, stated with the estimate: 10%; middle value at least 1.5-fold (0.18 log units) from the limit.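

In this assay compound 4 gives > 100 uM, which is a limit of the assay and not a number. Replacing a hydrogen with methyl, which turns hydroxymethyl into 1-hydroxyethyl, gives an at least 1.6-fold higher number from compound 3 to compound 4 (0.22 log units; that floor lies within the scatter), so only a floor for this step is known, and that floor does not clear the usual scatter of the assay. This leaves just one earlier example for comparison, with the methyl at a different place on the chain, so the data neither show that the change carries from one core to another with the same size nor show that it does not: the same change on two cores in this assay, a 1.3-fold higher number (0.12 log units; within the scatter) from compound 2 to compound 1 and an at least 1.6-fold higher number (0.22 log units; that floor lies within the scatter) from compound 3 to compound 4; the limit leaves it open whether they differ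

The compounds shown pair 1-hydroxyethyl only with the core of compound 4, so it remains open what the same group would do on the core of compound 1 or compound 2, where the side chains carry no hydroxyl. Also open, as far as these compounds go, is how far the number would move with a longer chain such as ethyl on that oxygen-bearing carbon, or with an amine in place of the hydroxyl.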